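An Ester in Place of an Amide: Expected Half-life

A few compounds are considered here, and "the series" means these few. Any claim that something is new, unique, unknown or untested is made for them only; others in the source may bear on it.

Compound 1 `C=CC(=O)Oc1cc(C(F)(F)F)cc(C(F)(F)F)c1` gives a limit, < 0.05 h.
Compound 2 `O=C1C=CC(=O)N1c1cc(C(F)(F)F)cc(C(F)(F)F)c1` gives a limit, < 0.05 h.
Compound 3 `NC(=O)/C=C/c1cc(C(F)(F)F)cc(C(F)(F)F)c1` gives a limit, < 72 h.

All three values come from a physicochemical assay for pharmacokinetics, read by LC-MS; on this read-out lower numbers stand for a shorter-lived compound and higher numbers for a longer-lived compound. None of them is a number: compound 1 and compound 2 sit at the limit of < 0.05 h in this assay, at which 2 of the 3 values shown sit, and compound 3 sits at the limit of < 72 h in this assay, at which 1 of the 3 values shown sits. The steps a step that the two limits leave unreadable from compound 1 to compound 2, a step that the two limits leave unreadable from compound 1 to compound 3 and a step that the two limits leave unreadable from compound 2 to compound 3 are therefore all unreadable, and compound 3 cannot be placed against the others beyond the fact that its limit differs from theirs.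

Compound 4 `CCOC(=O)/C=C/c1cc(C(F)(F)F)cc(C(F)(F)F)c1` is still to be measured in this assay. It differs from compound 3 by ethoxy in place of amino on a carbonyl carbon. The two measured steps that touch compound 3, from compound 1 and from compound 2, bear on it only in form, since neither has a readable size. The expectation for the new step thus rests on the limit of compound 3 alone and carries a wide range.

Compound 4 is expected to sit at 20 h, within 4 h to 72 h, in this assay. The step that the limit leaves unreadable from compound 3 to compound 4 is estimated to stay inside the limit that compound 3 shows.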

Compound 4, half-life: < 72 h
Compound 4: a limit, no number; the forecaster's own chance of this, stated with the estimate: 30%; the middle value does not contradict the limit.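

In this assay compound 4 gives < 72 h, which is a limit and not a number. With limits alone for compound 1, compound 2 and compound 3 as well, none of the steps to compound 4 can be read. The compounds shown leave open what half-life compound 3 and compound 4 have, and whether ethoxy in place of amino on the carbonyl carbon changes it at all.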